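A few compounds are considered here, and "the series" means these few. Any claim that something is new, unique, unknown or untested is made for them only; others in the source may bear on it.

Of the compounds shown here, three built on one shared core have been measured in a functional assay on HL-60 cells (Homo sapiens) for antiproliferative activity, read by MTT assay, with a stated time of 72 h; a lower number here means a stronger inhibitor, a higher number a weaker inhibitor. Compound 1 `CNc1nc(-c2cc(OC)c(OC)c(OC)c2)c(-c2ccc(C)cc2)s1` gives 18.1 nM, compound 2 `CCOc1ccc(-c2sc(NC)nc2-c2cc(OC)c(OC)c(OC)c2)cc1` gives 1.8 nM, and compound 3 `COc1cc(-c2nc(C)sc2-c2ccc(C)cc2)cc(OC)c1OC` gives 1510 nM. Compound 3 therefore has the highest number of the three, which makes it the weakest inhibitor here, and its gap to each of the other two lies beyond the scatter.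

Compound 4 `CCOc1ccc(-c2sc(C)nc2-c2cc(OC)c(OC)c(OC)c2)cc1` has not yet been measured. It differs from compound 3 in a single group: ethoxy in place of methyl on an aromatic carbon. This puts ethoxy in place of methyl on an aromatic carbon, turning 4-methylphenyl into 4-ethoxyphenyl.

The same exchange has been measured once, in the pair carrying methylamino, and there it gave a 10-fold lower number from compound 1 to compound 2 (1.00 log units; beyond the scatter). The other measured step, an 83-fold higher number from compound 1 to compound 3 (1.92 log units; beyond the scatter), is large and shows how far compound 3 sits from compound 1, but it cannot show whether the ethoxy gain carries over to the methyl series. Among the measured compounds shown here, with only one example to go on, a modest step towards a lower number is expected, with wide uncertainty.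

The step estimated on this basis is a 10-fold lower number from compound 3 to compound 4 (1.00 log units; beyond the scatter). For compound 4 the expected value in this assay is 150 nM, with an estimated range from 40 nM to 550 nM.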

Compound 4, half-maximal inhibitory concentration: 253 nM
Compound 4: middle estimate off by 1.7-fold (0.23 log units), on the low side; the measured number falls inside the stated range.
By their numbers in this assay, from the lowest: compound 2; then compound 1; then compound 4; then compound 3.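

In this assay, exchanging 4-methylphenyl for 4-ethoxyphenyl gives a 6.0-fold lower number from compound 3 to compound 4 (0.78 log units; beyond the scatter), so the gain no longer rests on the methylamino pair alone: the same change on two cores in this assay, a 10-fold lower number (1.00 log units; beyond the scatter) from compound 1 to compound 2 and a 6.0-fold lower number (0.78 log units; beyond the scatter) from compound 3 to compound 4, 1.7-fold (0.23 log units) apart, within the scatter of two such steps. The change from methylamino to methyl now also has a second example, a 140-fold higher number from compound 2 to compound 4 (2.15 log units; beyond the scatter), this time with 4-ethoxyphenyl in place of 4-methylphenyl: the same change on two cores in this assay, an 83-fold higher number (1.92 log units; beyond the scatter) from compound 1 to compound 3 and a 140-fold higher number (2.15 log units; beyond the scatter) from compound 2 to compound 4, 1.7-fold (0.23 log units) apart, within the scatter of two such steps. Across these four compounds, each change therefore keeps about the same size whichever group sits at the other place, none of the four goes against this, and the step between methylamino and methyl remains the larger of the two.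

The compounds shown do not separate the effect of the oxygen atom from that of the longer chain in ethoxy, a question that a methoxy group and a propoxy group at the same place could help to settle. On these data alone, at the other place, only methylamino and methyl appear, so it remains open how an unsubstituted amine or a dimethylamino group would compare there.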